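Imidazolylmethyl biaryls: pyrimidinyl in place of methylthiophenyl

This account rests on a few compounds, and the source may have more. Where it says the series, first, only, none or still open, it means among the compounds named here.

Measured so far in an assay for inhibition of steroid 17-alpha-hydroxylase/17,20 lyase (Homo sapiens), using NADPH, tested at 0.2 uM; on this read-out lower numbers stand for a weaker effect and higher numbers for a stronger effect at the one concentration tested:
compound 1 `c1cn(Cc2ccc(-c3ccoc3)cc2)cn1`: 3%
compound 2 `Cc1cscc1-c1ccc(Cn2ccnc2)cc1`: 0%

Compound 2 stands lowest of the two numbers in this assay; its nearest neighbour is compound 1, and the step of a number 3 percentage points lower from compound 1 to compound 2 (within the scatter) lies within the scatter. Both numbers sit at the floor of the read-out, so neither biaryl partner tried so far gives any measurable effect at this concentration.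

Compound 3 `c1cn(Cc2ccc(-c3cncnc3)cc2)cn1` differs from compound 2 by pyrimidin-5-yl in place of 4-methylthiophen-3-yl on an aromatic carbon. Among the compounds with values here, no measured step carries a pyrimidin-5-yl or any six-membered aromatic partner ring; the single step known, from compound 1 to compound 2, swapped one five-membered aromatic ring for another and moved nothing beyond the scatter. There is therefore no measured basis for a step in either direction. Compound 3 is expected to give 5%, with a range of -5% to 25%. For compound 3 the implied step a number 5 percentage points higher from compound 2 to compound 3 (within the scatter) is expected to stay within the scatter.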

Compound 3, a percentage reported as inhibition, at one concentration (the size of the read-out at that concentration, not a potency): 5%
The estimate for compound 3 equals the measured number at the digits printed; measured number inside the range.
By their numbers in this assay, from the lowest: compounds 2, 1 and 3 (each within the scatter of the next).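

In this assay, the first six-membered aromatic partner ring on this carbon, para to a (1H-imidazol-1-yl)methyl group, leaves the read-out at the floor: pyrimidin-5-yl in place of 4-methylthiophen-3-yl gives a number 5 percentage points higher from compound 2 to compound 3 (within the scatter), and pyrimidin-5-yl in place of furan-3-yl gives a number 2 percentage points higher from compound 1 to compound 3 (within the scatter). At this single concentration, then, neither the larger ring nor the 2 ring hetero atoms of pyrimidin-5-yl separate compound 3 from compound 1 or compound 2. Nothing measured on these compounds offers an account of the numbers.

From the compounds shown here alone, it remains open whether any partner at this position can lift the read-out clear of the floor, for instance a phenyl ring bearing an amine or a carboxylic acid. Also open, going by these compounds, is whether a change to the (1H-imidazol-1-yl)methyl group, such as a longer chain to the imidazole, would move the number.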